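A Single Amino Group on a Cinnamamide Arm

The source may hold more compounds than are shown below. What is called first, only, known or untested is meant among the compounds shown, and "the series" means these compounds.

Two compounds share a core in which a trimethoxybenzoyl unit is joined to an anilide bearing a cinnamoyl arm. Compound 1 `COc1ccc(C(=O)c2cc(OC)c(OC)c(OC)c2)cc1NC(=O)/C=C/c1ccc(F)c(F)c1` carries two fluorine atoms on the arm, and in a functional assay on ME-180 cells (Homo sapiens) for cytotoxicity, read by MTT assay, with a stated time of 72 h (on this read-out lower numbers stand for stronger inhibition and higher numbers for weaker inhibition), compound 1 gives 8900 nM. Compound 2 `COc1ccc(/C=C/C(=O)Nc2cc(C(=O)c3cc(OC)c(OC)c(OC)c3)cc(OC)c2OC)cc1OC` carries two methoxy groups there instead, and in this assay compound 2 gives 6700 nM. Compound 2 stands at the low end of these two numbers, yet the gap from compound 1 lies within the usual scatter, so the two are not separated by the measurements.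

Compound 3 `COc1ccc(/C=C/C(=O)Nc2cc(C(=O)c3cc(OC)c(OC)c(OC)c3)cc(OC)c2OC)cc1N` has not yet been measured. It differs from compound 2 by amino in place of methoxy on an aromatic carbon. Among the compounds with values here, no measured pair shows this change, so the expectation rests on the structures alone. The estimated step is a 1.9-fold lower number from compound 2 to compound 3 (0.28 log units; within the scatter). Compound 3 is therefore expected to give about 3500 nM in this assay, with a range from 900 nM to 14000 nM.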

Compound 3, half-maximal inhibitory concentration: 13900 nM
Estimate against measurement, compound 3: 4.0-fold (0.60 log units) below, and the stated range covers the measured number.
By their numbers in this assay, from the lowest: compounds 2, 1 and 3 (each within the scatter of the next, the first and the last beyond it).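

In this assay, turning the 3,4-dimethoxyphenyl end of the arm into a 3-amino-4-methoxyphenyl end gives a 2.1-fold higher number from compound 2 to compound 3 (0.32 log units; beyond the scatter). Within the data shown here, this is the first comparison here in which two compounds differ in one place only, and it shows that this position, ortho to a methoxy group and meta to a large group, responds to the swap: the step is modest, but it lies beyond the usual scatter, and on this read-out a higher number means weaker inhibition, so here the amino group gives up some cytotoxic strength relative to the methoxy group. No measurement shown here accounts for this difference.

This single pair leaves open how other groups at the same position, such as a hydroxyl, a dimethylamino group or a fluorine atom, would compare with the methoxy and amino groups. It also leaves open whether an amino group in place of a methoxy group on the other aromatic rings of the shared core would move the number in the same direction.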